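Changing one of two stereocentres in compound 2

A few compounds are considered here, and "the series" means these few. Any claim that something is new, unique, unknown or untested is made for them only; others in the source may bear on it.

Measured in a functional assay on A549 cells (Homo sapiens) for cytotoxicity, read by MTT assay, with a stated time of 48 h; a lower number here means a stronger inhibitor, a higher number a weaker inhibitor:
- compound 1 `CCOC(=O)[C@]1(C(=O)NCc2ccc(C)cc2)C[C@H]1c1cc(OC)c(OC)c(OC)c1`: 13300 nM
- compound 2 `CCOC(=O)[C@@]1(C(=O)NCc2ccc(C)cc2)C[C@@H]1c1cc(OC)c(OC)c(OC)c1`: > 100000 nM (a limit of the assay, not a number)
- compound 3 `CCOC(=O)C1(C(=O)NCc2ccc(C)cc2)CC1c1cc(OC)c(OC)c(OC)c1`: 18700 nM; 21400 nM (2 entries)

Compound 2 offers no exact starting value, since its > 100000 nM is only a limit. Compound 4 `CCOC(=O)[C@]1(C(=O)NCc2ccc(C)cc2)C[C@@H]1c1cc(OC)c(OC)c(OC)c1` keeps the atoms and bonds of compound 2 but changes its drawn shape: the two compounds have the same atoms and bonds and differ only in configuration as drawn: 1 of 2 stereo elements differ; a stereocentre at a saturated ring carbon is drawn S in compound 2 and R in compound 4.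

The closest measured comparison is an at least 7.5-fold higher number from compound 1 to compound 2 (0.87 log units; beyond the scatter), which reflects (the fact that compounds 1 and 2 differ only in the configuration as drawn). That step inverts both stereocentres, whereas the new change inverts only one, so it offers a guide to direction but no direct measure of size. Compound 3 adds (the several entries of compound 3 in this assay, 18700 nM; 21400 nM (2 entries)), but the fact that one of compounds 2 and 3 is drawn with a defined configuration and the other without, at the place where they differ limits what it can say about any single form.

Compound 2 sits at the weak end of the series, so a move toward a lower number in this assay seems more likely than not. The expected change is an at least 2.8-fold lower number from compound 2 to compound 4 (0.45 log units; beyond the scatter), though its size is uncertain. For compound 4, the estimated value is 35000 nM, within an expected range of 10000 nM to 100000 nM.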

Compound 4, half-maximal inhibitory concentration: 34900 nM
Compound 4: middle estimate off by 1.0-fold (0.00 log units), on the high side; the range from low to high includes it.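

In this assay, inverting a single stereocentre is enough to shift the result, which the earlier pair could not show because it changed both stereocentres at once: an at least 2.8-fold lower number from compound 2 to compound 4 (0.45 log units; beyond the scatter). Inverting the other stereocentre, starting from compound 1, also moves the number beyond the scatter, so neither centre is silent on its own: a 2.6-fold higher number from compound 1 to compound 4 (0.42 log units; beyond the scatter). From the compounds shown here alone, compound 2 has only a limit of the assay, > 100000 nM, so the true size of the first step stays unknown.

All of these compounds share the same atoms, so they cannot tell how the mirror image of compound 4 would behave. They also leave open whether this preference for one shape would survive if a carboxylic acid replaced the ethyl ester on the shared core.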